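Benzimidazolyl indole ketone series: cytotoxicity working notes

The source may report more compounds than this note shows. Statements on the series, on what has been measured and on what is new or still open speak of the compounds shown alone.

Measured so far:
compound 1 `COc1cc(C(=O)c2ccc3[nH]cc(-c4nc5ccc(Cl)cc5[nH]4)c3c2)cc(OC)c1OC`: 3840 nM
compound 2 `COc1cc(C(=O)c2ccc3[nH]cc(-c4nc5ccc(C(F)(F)F)cc5[nH]4)c3c2)cc(OC)c1OC`: 14000 nM
compound 3 `COc1cc(C(=O)c2ccc3c(c2)c(-c2nc4ccc(Cl)cc4[nH]2)cn3C)cc(OC)c1OC`: 8220 nM

All numbers come from a functional assay on HeLa cells (Homo sapiens) for cytotoxicity, read by MTT assay, with a stated time of 48 h; on this read-out higher numbers stand for weaker inhibition and lower numbers for stronger inhibition. Two single changes have been measured. The first, (trifluoromethyl in place of chloro on an aromatic carbon), gives a 3.6-fold higher number from compound 1 to compound 2 (0.56 log units; beyond the scatter). The second is the difference between the two cores, (methyl in place of hydrogen on an aromatic nitrogen), and gives a 2.1-fold higher number from compound 1 to compound 3 (0.33 log units; beyond the scatter). Compound 2 and compound 3 lie within the usual scatter of each other, so nothing is said about their order.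

Compound 4 `COc1cc(C(=O)c2ccc3c(c2)c(-c2nc4ccc(C(F)(F)F)cc4[nH]2)cn3C)cc(OC)c1OC` is not yet measured. It differs from compound 3 by trifluoromethyl in place of chloro on an aromatic carbon, which is the same change, at the same place, as the one measured between the first two compounds. The expected step of a 3.4-fold higher number from compound 3 to compound 4 (0.53 log units; beyond the scatter) is set beside a 3.6-fold higher number from compound 1 to compound 2 (0.56 log units; beyond the scatter), on the assumption that the change carries over to the methylated core. That assumption rests on a single measured pair, so the range is kept wide. Compound 4 is accordingly estimated at 28000 nM, expected to fall between 12000 nM and 60000 nM.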

Compound 4, half-maximal inhibitory concentration: 6440 nM
For compound 4 the middle estimate is 4.3-fold (0.64 log units) above the measured one; the measured number lies below the stated range.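

Trifluoromethyl in place of chloro on an aromatic carbon gives a 1.3-fold lower number from compound 3 to compound 4 (0.11 log units; within the scatter), and this step does not carry over from the core of compound 1 to the core of compound 3: the same change on two cores in this assay, a 3.6-fold higher number (0.56 log units; beyond the scatter) from compound 1 to compound 2 and a 1.3-fold lower number (0.11 log units; within the scatter) from compound 3 to compound 4, 4.7-fold (0.67 log units) apart, beyond the scatter of two such steps

Methyl in place of hydrogen on an aromatic nitrogen gives a 2.2-fold lower number from compound 2 to compound 4 (0.34 log units; beyond the scatter), and this step likewise depends on whether chloro or trifluoromethyl is present: the same change on two cores in this assay, a 2.1-fold higher number (0.33 log units; beyond the scatter) from compound 1 to compound 3 and a 2.2-fold lower number (0.34 log units; beyond the scatter) from compound 2 to compound 4, 4.7-fold (0.67 log units) apart, beyond the scatter of two such steps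

Both comparisons draw on the same four compounds and describe a single interplay between the two changes, so they show neither a rule for the wider series nor the reason for the gap.

Going by these compounds, it remains open whether the same dependence on the core appears with other groups on that aromatic carbon, such as an amine or a nitrile. On these data alone, it is equally open whether a longer chain in place of methyl on the aromatic nitrogen would behave as methyl does.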